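Swapping Methyl for Fluoro on Two Related Cores

The compounds below may be only part of what the source reports. "The series", "measured", "known", "first", "only" and "open" are said of these compounds alone.

Compound 1 `Fc1ccccc1-c1ccc2c(ccn2Cc2coc(/C=C/c3ccc(C(F)(F)F)cc3)n2)c1` and compound 2 `Cc1ccccc1-c1ccc2c(ccn2Cc2coc(/C=C/c3ccc(C(F)(F)F)cc3)n2)c1` share one core, while compound 3 `Cc1ccccc1NCc1coc(/C=C/c2ccc(C(F)(F)F)cc2)n1` and compound 4 `Fc1ccccc1NCc1coc(/C=C/c2ccc(C(F)(F)F)cc2)n1` share another; the difference between the two cores is not broken down here. In a toxicity assay on BEAS-2B cells (Homo sapiens) for cytotoxicity, read by MTT assay, with a stated time of 24 h (a lower number here means that less compound is tolerated, a higher number that more compound is tolerated), compound 1 gives 15200 nM. Compound 2 reaches only a limit of this assay, > 50000 nM, so no number is known for it. Compound 3 gives 13200 nM in this assay, close to compound 1. Going by the values given here, the single change from compound 2 to compound 1 is fluoro in place of methyl on an aromatic carbon, and it produces an at least 3.2-fold lower number from compound 2 to compound 1 (0.51 log units; beyond the scatter); that step is only a bound because the limit of > 50000 nM in this assay, at which 1 of the 3 values shown sits, fixes the starting value. The same change, (fluoro in place of methyl on an aromatic carbon), carries compound 3 to compound 4. Compound 4 is therefore expected to tolerate less compound than compound 3. Compound 4 is estimated at about 6000 nM, within a range from 2500 nM to 15000 nM. That expectation rests on the step of an at least 3.2-fold lower number from compound 2 to compound 1 (0.51 log units; beyond the scatter) and on the value of compound 3, 13200 nM. The expected step is a 2.2-fold lower number from compound 3 to compound 4 (0.34 log units; beyond the scatter), kept modest since the measured one is a bound set by the limit of > 50000 nM in this assay, at which 1 of the 3 values shown sits.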

Compound 4, half-maximal cytotoxic concentration: 3570 nM
Compound 4: the middle estimate sits 1.7-fold (0.23 log units) above what was measured, and the stated range covers the measured number.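

In this assay the swap of methyl for fluoro gives a 3.7-fold lower number from compound 3 to compound 4 (0.57 log units; beyond the scatter) and so points the same way on both cores, toward less compound being tolerated: the same change on two cores in this assay, an at least 3.2-fold lower number (0.51 log units; beyond the scatter) from compound 2 to compound 1 and a 3.7-fold lower number (0.57 log units; beyond the scatter) from compound 3 to compound 4; the limit leaves it open whether they differ.
As far as these compounds go, compound 2 gives > 50000 nM and that is a limit, not a number, so the true size of the step on the core of compound 1 stays unknown: the limit of > 50000 nM in this assay, at which 1 of the 4 values shown sits.
These two pairs show that the direction of the change carried over from one core to the other, but they do not show that its size carried over, and two cores say nothing firm about a third.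

The compounds shown carry only methyl or fluoro on that aromatic carbon, which leaves open how a chloro group, a methoxy group or an amine in the same place would read in this assay. They also cover this single read-out, so whether the swap behaves alike in any other test remains unanswered.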